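A few compounds are considered here, and "the series" means these few. Any claim that something is new, unique, unknown or untested is made for them only; others in the source may bear on it.

The compounds measured in an ADME assay on Vero cells (Chlorocebus sabaeus) for cytotoxicity; on this read-out higher numbers stand for lower toxicity in this test and lower numbers for higher toxicity in this test:
Compound 1 `Cn1c(-c2ccc([N+](=O)[O-])cc2)nc2cc(C(F)(F)F)ccc21` gives > 100000 nM, which is a limit of the assay and not a number.
Compound 2 `Cn1c(-c2ccc(NC(=O)CN3CCCC3)cc2)nc2cc(C(F)(F)F)ccc21` gives > 100000 nM, likewise a limit.
Compound 3 `O=C(CN1CCCC1)Nc1ccc(-c2nc3cc(Cl)c(Cl)cc3[nH]2)cc1` gives > 100000 nM, also a limit.

Compound 2 therefore stands only at a limit in this assay, as does every value shown here: the limit of > 100000 nM in this assay, at which 3 of the 3 values shown sit. For the measured compounds named here, the single measured step, a step that the two limits leave unreadable from compound 1 to compound 2, runs between two limits and gives no readable size. Compound 4 `CCN(CC)CC(=O)Nc1ccc(-c2nc3cc(C(F)(F)F)ccc3n2C)cc1` differs from compound 2 by diethylamino in place of pyrrolidin-1-yl on a saturated chain carbon bound to a carbonyl carbon. Going by the values given here, no measured step can size this change. With three limits and nothing readable, compound 4 is expected to stay at the limit, a step that the limit leaves unreadable from compound 2 to compound 4 that is not expected to reach beyond the scatter. The estimate for compound 4 in this assay is 150000 nM, between 80000 nM and 300000 nM.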

Compound 4, half-maximal cytotoxic concentration: 90000 nM
The estimate for compound 4 lay 1.7-fold (0.22 log units) above the measured number, within the range that was stated.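

In this assay, for the compounds shown here, compound 4 gives 90000 nM as the first reading here that is a number and not a limit. Diethylamino in place of pyrrolidin-1-yl amounts to an at least 1.1-fold lower number from compound 2 to compound 4 (0.04 log units; that floor lies within the scatter) and the whole side group in place of nitro amounts to an at least 1.1-fold lower number from compound 1 to compound 4 (0.04 log units; that floor lies within the scatter) with neither floor clearing the scatter. The true size of both steps stays unreadable because each starts from a limit: the limit of > 100000 nM in this assay, at which 3 of the 4 values shown sit.

From the compounds shown here alone, what a piperidine or morpholine ring would give on the same saturated chain carbon remains open. So does the effect of a longer chain between the carbonyl and the amine.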